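Fluoro for Trifluoromethyl on the Aryl Arm

The source may hold more compounds than are shown below. What is called first, only, known or untested is meant among the compounds shown, and "the series" means these compounds.

For the measured compounds named here, compound 2 `C=CCn1c(=O)/c(=C\c2ccccc2C(F)(F)F)[nH]c(=O)/c1=C\c1ccccc1OC` stands at the top of the two numbers measured so far. In a functional assay on NCI-H1975 cells (Homo sapiens) for cytotoxicity, read by CCK-8 assay, with a stated time of 72 h (on this read-out higher numbers stand for weaker inhibition and lower numbers for stronger inhibition), compound 2 gives 14500 nM. Going by the values given here, its only neighbour, compound 1 `C=CCn1c(=O)/c(=C\c2cccc(Cl)c2Cl)[nH]c(=O)/c1=C\c1ccccc1OC`, gives 4500 nM in this assay, and the single measured step, a 3.2-fold higher number from compound 1 to compound 2 (0.51 log units; beyond the scatter), shows that exchanging the group on this aryl arm moves the number by a modest amount, beyond the scatter.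

Compound 3 `C=CCn1c(=O)/c(=C\c2ccccc2F)[nH]c(=O)/c1=C\c1ccccc1OC` has not been measured. It differs from compound 2 in one place: fluoro in place of trifluoromethyl on an aromatic carbon. Among the compounds with values here, no measured pair covers this exact exchange. Within the data shown here, the only step that bears on it, a 3.2-fold higher number from compound 1 to compound 2 (0.51 log units; beyond the scatter), was modest, and it suggests that swapping one group for another on this ring changes the number by a modest amount in either direction. Compound 3 is therefore expected to give about 8000 nM in this assay, with a plausible range from 3000 nM to 25000 nM. The expected step, a 1.8-fold lower number from compound 2 to compound 3 (0.26 log units; within the scatter), is estimated to be small, toward a lower number, and may well remain within the scatter.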

Compound 3, half-maximal inhibitory concentration: 25100 nM
For compound 3 the middle estimate is 3.1-fold (0.50 log units) below the measured one; measured number outside the range, above it.
By their numbers in this assay, from the lowest: compound 1; then compounds 2 and 3 (each within the scatter of the next).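

In this assay, trading trifluoromethyl for fluoro on this aromatic carbon removes three of the four heavy atoms of the group, yet the result is only a 1.7-fold higher number from compound 2 to compound 3 (0.24 log units; within the scatter), so compounds 2 and 3 cannot be told apart on this read-out. The 2,3-dichlorophenyl arm of compound 1 now stands apart from two different arms, as the new comparison gives a 5.6-fold higher number from compound 1 to compound 3 (0.75 log units; beyond the scatter) and the step to compound 2 was also beyond the scatter. Among these three compounds, the size of the single group on this ring therefore makes no measurable difference, while compound 1 has the lowest number and so the strongest inhibition; nothing available explains why these numbers fall as they do.

As far as these compounds go, it remains open whether the lower number of compound 1 goes with chlorine as such, with the second chlorine, or with the place that the second chlorine occupies, and a single chloro on this ring would help to separate these readings. From the compounds shown here alone, it is also open what a more different group at this place, such as an amine or a carboxylic acid, would do to the number.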